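This account rests on a few compounds, and the source may have more. Where it says the series, first, only, none or still open, it means among the compounds named here.

Compound 1 `COc1cc(N2C(=O)C(OC(C)=O)C2c2ccc([N+](=O)[O-])o2)cc(OC)c1OC` gives 811 nM in a functional assay on IMR-32 cells (Homo sapiens) for cytotoxicity; a higher number here means a weaker inhibitor, a lower number a stronger inhibitor. Compound 2 `COc1cc(N2C(=O)C(OC(C)=O)C2c2ccc(N)o2)cc(OC)c1OC` reaches only the limit of this assay, > 1000 nM, so for compound 2 a limit rather than a number is known.

Compound 2 therefore stands at the weaker end of the two values shown; the step of an at least 1.2-fold higher number from compound 1 to compound 2 (0.09 log units; that floor lies within the scatter) carries it to the limit (the limit of > 1000 nM in this assay, at which 1 of the 2 values shown sits).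

Compound 3 `COc1cc(N2C(=O)C(OC(C)=O)C2c2ccc(N(C)C)cc2)cc(OC)c1OC` differs from compound 2 by 4-(dimethylamino)phenyl in place of 5-aminofuran-2-yl on a saturated ring carbon. For the measured compounds named here, no measured step covers this kind of change: the only measured step, an at least 1.2-fold higher number from compound 1 to compound 2 (0.09 log units; that floor lies within the scatter), exchanges the nitro for an amino group on the same furan, whereas here the whole 5-aminofuran-2-yl group gives way to a 4-(dimethylamino)phenyl group. With compound 2 itself known only as a limit, the expectation for compound 3 is a value near that limit, with a wide range. Compound 3 is expected to give 1500 nM in this assay, between 500 nM and 5000 nM. The estimated step that the limit leaves unreadable from compound 2 to compound 3 rests on the limit alone, not on any measured step.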

Compound 3, half-maximal inhibitory concentration: 520 nM
The estimate for compound 3 lay 2.9-fold (0.46 log units) above the measured number; low and high end bracket the measured number.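

Putting 4-(dimethylamino)phenyl in place of 5-aminofuran-2-yl on the saturated ring carbon gives an at least 1.9-fold lower number from compound 2 to compound 3 (0.28 log units; that floor lies within the scatter) in this assay. That step can be read only as a floor because compound 2 has a limit and not a number: the limit of > 1000 nM in this assay, at which 1 of the 3 values shown sits. Against the nitro-bearing furan the same exchange gives a 1.6-fold lower number from compound 1 to compound 3 (0.19 log units; within the scatter), so in this pair a furan is not required at this position for a value of this size, and a six-membered carbon ring serves equally well.

Going by these compounds, what remains open is whether the ring or its dimethylamino group matters here: a plain phenyl, or a phenyl carrying a primary amine, would tell the two apart. The compounds shown also leave open what the neighbouring acetoxy group contributes, which a free hydroxyl in its place would test.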